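The compounds below may be only part of what the source reports. "The series", "measured", "known", "first", "only" and "open" are said of these compounds alone.

Within the data shown here, compound 1 `CCCCCc1c(C(C)C)nc(C(C)C)c(CO)c1-c1ccc(F)cc1F` stands with the highest number of the two compounds measured so far in an assay on CHO cells for inhibition of Glucagon receptor (Homo sapiens) (on this read-out lower numbers stand for stronger inhibition and higher numbers for weaker inhibition), where compound 1 gives 11000 nM. Its nearest neighbour, compound 2 `CCCCCc1c(C(C)C)nc(C(C)C)c(CO)c1-c1ccc(C)cc1`, gives 1000 nM in this assay. Among the measured compounds shown here, the single step between them, an 11-fold lower number from compound 1 to compound 2 (1.04 log units; beyond the scatter), came with 4-methylphenyl in place of 2,4-difluorophenyl. Compound 3 `CCCCCc1c(C(C)C)nc(C(C)C)c(CO)c1-c1ccccc1O` differs from compound 1 by 2-hydroxyphenyl in place of 2,4-difluorophenyl on an aromatic carbon. For the measured compounds named here, no measured step involves a hydroxyl on this ring, so the change is not directly covered. Because an 11-fold lower number from compound 1 to compound 2 (1.04 log units; beyond the scatter) shows that exchanging the 2,4-difluorophenyl of compound 1 for another ring can lower the number by a large step, a step in the same direction but of smaller size is expected in this assay, estimated as a 2.8-fold lower number from compound 1 to compound 3 (0.44 log units; beyond the scatter). For compound 3 the expected value is 4000 nM, with a range from 1000 nM to 16000 nM.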

Compound 3, half-maximal inhibitory concentration: 500 nM
The estimate for compound 3 lay 8.0-fold (0.90 log units) above the measured number; the whole stated range lies above it.
By their numbers in this assay, from the lowest: compounds 3 and 2 (each within the scatter of the next); then compound 1.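

In this assay the position opposite the ring nitrogen now has a second replacement for the 2,4-difluorophenyl that gives a large step (a 22-fold lower number from compound 1 to compound 3 (1.34 log units; beyond the scatter)), so that step no longer rests on 4-methylphenyl alone. The two replacements stand within the scatter of each other (a 2.0-fold lower number from compound 2 to compound 3 (0.30 log units; within the scatter)), although 2-hydroxyphenyl brings a hydroxyl and 4-methylphenyl a methyl, which leaves only the 2,4-difluorophenyl of compound 1 apart from the others. Nothing available explains these numbers.

The compounds leave open whether the hydroxyl contributes at all, which unsubstituted phenyl, 2-methoxyphenyl or 4-hydroxyphenyl would test, and whether both fluorines or only one goes with the high number of compound 1. Going by these compounds, how an amine or a carboxylic acid on this ring would read also remains open.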